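The compounds below may be only part of what the source reports. "The series", "measured", "known", "first", "only" and "open" are said of these compounds alone.

In a physicochemical assay for lipophilicity (on this read-out lower numbers stand for lower lipophilicity and higher numbers for higher lipophilicity), compound 1 `O=C(CN(C(=O)c1cccnc1)C1CCCCC1)Nc1cc(F)cc(F)c1` gives 2.7, while the entry for compound 2 `O=C(CN(C(=O)c1cccc(Cl)c1)C1CCCCC1)Nc1cc(F)cc(F)c1` reads "not determined" (no result reported). Compound 3 `O=C(CN(CC1CC1)C(=O)c1ccc(-c2ccccn2)cc1)Nc1cc(F)cc(F)c1` gives 3.1, the higher of the two available numbers. Its gap to compound 1 lies beyond the usual scatter, but those two compounds differ in more than one place, so the gap cannot be assigned to any single group.

Compound 4 `CCC(COC)N(CC(=O)Nc1cc(F)cc(F)c1)C(=O)c1ccc(-c2ccccn2)cc1` has not yet been measured in this assay. It differs from compound 3 at one place, with 1-(methoxymethyl)propyl in place of cyclopropylmethyl on an amide-type nitrogen. Within the data shown here, no measured pair differing in one place is available to size such a change, so the expectation stays close to compound 3 at 3.1, with no step beyond the scatter in either direction. The estimated change is a number 0.10 log units lower from compound 3 to compound 4 (within the scatter). For compound 4 the expected value is 3, within an estimated range from 2.6 to 3.4.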

Compound 4, distribution coefficient: 3.3
Estimate against measurement, compound 4: 0.30 log units below; low and high end bracket the measured number.
By their numbers in this assay, from the lowest: compound 1; then compounds 3 and 4 (each within the scatter of the next).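

In this assay, the first step measured at this position is a number 0.20 log units higher from compound 3 to compound 4 (within the scatter), with 1-(methoxymethyl)propyl in place of cyclopropylmethyl on an amide-type nitrogen. The exchange gives up the three-membered ring and brings in an oxygen and a hydrogen-bond acceptor, with the heavy atoms going from 4 to 6, yet the two compounds cannot be told apart on this read-out, so this one exchange at this position leaves the number unresolved from that of compound 3. Nothing in the available data accounts for this outcome.

As far as these compounds go, whether a chain carrying an amine or a carboxylic acid on the same nitrogen would stay within the scatter of compound 3 remains open. A single step also cannot show whether the same exchange would give a similar result on another core.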